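Replacing the chain of compound 2 with an aromatic ring

This account rests on a few compounds, and the source may have more. Where it says the series, first, only, none or still open, it means among the compounds named here.

In a functional assay on MV4-11 cells (Homo sapiens) for antiproliferative activity, read by CCK-8 assay, with a stated time of 72 h (a higher number here means a weaker inhibitor, a lower number a stronger inhibitor), compound 2 `Cn1cc(-c2ccccc2Oc2ccccc2)c2cc(C(=O)NCCCCCC(=O)NO)[nH]c2c1=O` gives 610 nM, the weakest of the three measured compounds. Compound 1 `Cn1cc(-c2ccccc2Oc2ccccc2)c2cc(C(=O)NCCCCCCC(=O)NO)[nH]c2c1=O` gives 180 nM, and compound 3 `Cc1cc(F)cc(C)c1Oc1ccc(C(C)(C)O)cc1-c1cn(C)c(=O)c2[nH]c(C(=O)NCc3ccc(C(=O)Nc4ccccc4N)cc3)cc12` gives 240 nM.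

Compound 4 `Cn1cc(-c2ccccc2Oc2ccccc2)c2cc(C(=O)NCc3ccc(C(=O)NO)cc3)[nH]c2c1=O` differs from compound 2 in one place: 4-(hydroxycarbamoyl)phenyl in place of 4-(hydroxycarbamoyl)butyl on a saturated chain carbon bound to an amide-type nitrogen. Among the measured compounds shown here, no measured pair isolates this exchange of a chain for a ring. For the measured compounds named here, the closest evidence is the one measured step on the chain, a 3.4-fold higher number from compound 1 to compound 2 (0.53 log units; beyond the scatter), which is modest but beyond the scatter and shows that this assay responds to changes in this part of the structure. Compound 3, at 240 nM, also has an aromatic ring in this stretch but differs in other places too, so it offers only weak guidance. Its value still points towards a lower number, so a modest move in that direction is expected. The expected change is a 1.7-fold lower number from compound 2 to compound 4 (0.24 log units; within the scatter), with wide uncertainty. For compound 4 the estimated value is 350 nM, with an expected range of 120 nM to 1000 nM.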

Compound 4, half-maximal inhibitory concentration: 570 nM
For compound 4 the middle estimate is 1.6-fold (0.21 log units) below the measured one; measured number inside the range.
By their numbers in this assay, from the lowest: compounds 1 and 3 (each within the scatter of the next); then compounds 4 and 2 (each within the scatter of the next).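

In this assay, the aromatic ring can stand in for the chain at this position with no readable effect: the exchange of 4-(hydroxycarbamoyl)butyl for 4-(hydroxycarbamoyl)phenyl gives a 1.1-fold lower number from compound 2 to compound 4 (0.03 log units; within the scatter). The ring does not match the longer chain, since 5-(hydroxycarbamoyl)pentyl replaced by 4-(hydroxycarbamoyl)phenyl gives a 3.2-fold higher number from compound 1 to compound 4 (0.50 log units; beyond the scatter), a modest step, so the chain sensitivity seen earlier does not turn into a gain once the ring is present. No measurement at hand accounts for either result.

Still open, from the compounds shown here alone, is whether a chain longer than 5-(hydroxycarbamoyl)pentyl would continue the trend seen between the two chains. Also open, going by these compounds, is how this assay responds when a carboxylic acid replaces the hydroxycarbamoyl end on the chain or on the ring.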